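Replacing the selenium-bearing chain of compound 2

This account rests on a few compounds, and the source may have more. Where it says the series, first, only, none or still open, it means among the compounds named here.

Three compounds of the series have numbers in a functional assay on HCT-116 cells (Homo sapiens) for inhibition, read by MTT assay, with a stated time of 48 h; on this read-out lower numbers stand for stronger inhibition and higher numbers for weaker inhibition. Compound 1 `Cc1nc(N(C)c2ccc([Se]C#N)c(C)c2)c2ccccc2n1` gives 13 nM, compound 2 `COc1ccc(N(C)c2nc(C)nc3ccccc23)cc1C(=O)OCCC[Se]C#N` gives 720 nM and compound 3 `Cc1nc(N(C)c2ccc(OCC[Se]C#N)cc2)c2ccccc2n1` gives 2290 nM. Compound 2 therefore holds the middle place of the three, separated from each of the others by more than the scatter and lying closer to compound 3 than to compound 1.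

The next compound is compound 4 `COc1ccc(N(C)c2nc(C)nc3ccccc23)cc1OCCN`, which keeps the shared core and the methoxy group of compound 2. The change is a group of 4 heavy atoms (2 carbon, 1 nitrogen, 1 oxygen; no ring) in place of a group of 9 heavy atoms (5 carbon, 1 nitrogen, 2 oxygen, 1 selenium; no ring), on an aromatic carbon. The entering group is 2-aminoethoxy, ortho to a methoxy group and meta to a large group.

All three measured compounds carry selenium, and compound 4 carries none. Among the measured compounds shown here, no measured pair differs in one place, so the data give no direct guide to this change. For the measured compounds named here, the only guide is the spread of values, from compound 1 at 13 nM to compound 3 at 2290 nM. In this assay, no step beyond the scatter is the working expectation, with either direction open and wide uncertainty. The expected size is a 1.4-fold lower number from compound 2 to compound 4 (0.16 log units; within the scatter), an estimate only. In this assay the estimated value for compound 4 is 500 nM, with an expected range from 50 nM to 5000 nM.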

Compound 4, half-maximal inhibitory concentration: 198 nM
Compound 4: middle estimate off by 2.5-fold (0.40 log units), on the high side; measured number inside the range.
By their numbers in this assay, from the lowest: compound 1; then compound 4; then compound 2; then compound 3.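

In this assay, among the compounds shown here, putting 2-aminoethoxy in place of the selenium-bearing chain on this aromatic carbon, ortho to a methoxy group, gives a 3.6-fold lower number from compound 2 to compound 4 (0.56 log units; beyond the scatter) and this is the only step that can be read across a single place. For the compounds shown here, all the earlier compounds carried selenium, so they could not show what compound 4 now shows: at this position the selenium-bearing chain is not required for inhibition on these cells, and a much smaller group with a primary amine gives a number beyond the scatter on the stronger side of compound 2. Nothing measured bears on why this step arises.

The change removes the selenium, the nitrile and the ester carbonyl and shortens the chain all at once, so the compounds shown do not separate the share of each. A 3-aminopropoxy chain, a 2-hydroxyethoxy chain or a 2-(dimethylamino)ethoxy chain on the same aromatic carbon would test whether the primary amine, the chain length or the ether oxygen carries the step.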